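The source may hold more compounds than are shown below. What is called first, only, known or untested is meant among the compounds shown, and "the series" means these compounds.

Compound 1 `CC1=C(/C=C/C(=O)/C=C/c2ccc(Cl)cc2)C(C)(C)CCC1`: 90600 nM
Compound 2 `CC1=C(/C=C/C(=O)/C=C/c2ccc(C#N)cc2)C(C)(C)CCC1`: 45600 nM
Compound 3 `COc1ccc(/C=C/C(=O)/C=C/C2=C(C)CCCC2(C)C)cc1`: > 100000 nM, a limit of the assay rather than a number

In a functional assay on Hep cells (Homo sapiens) for cytotoxicity, read by sulforhodamine B assay, with a stated time of 48 h (a lower number here means a stronger inhibitor, a higher number a weaker inhibitor), compound 1 gives 90600 nM. Its nearest neighbour is compound 2, with a 2.0-fold lower number from compound 1 to compound 2 (0.30 log units; within the scatter). For compound 3 only a limit is reported, namely (the limit of > 100000 nM in this assay, at which 1 of the 3 values shown sits). Compound 4 `CC1=C(/C=C/C(=O)/C=C/c2ccccc2Cl)C(C)(C)CCC1` differs from compound 1 by 2-chlorophenyl in place of 4-chlorophenyl on a double-bonded chain carbon bound to a double-bonded chain carbon. Within the data shown here, none of the measured steps bears on this change: the steps of an at least 1.1-fold higher number from compound 1 to compound 3 (0.04 log units; that floor lies within the scatter) and an at least 2.1-fold higher number from compound 2 to compound 3 (0.34 log units; beyond the scatter) exchange one group for another at the same place, and no step moves a group around the aromatic ring. No step beyond the scatter is therefore expected in this assay. Compound 4 is estimated at 90000 nM, with a range of 30000 nM to 200000 nM, an expected step of a 1.0-fold lower number from compound 1 to compound 4 (0.00 log units; within the scatter).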

Compound 4, half-maximal inhibitory concentration: 54200 nM
Estimate against measurement, compound 4: 1.7-fold (0.22 log units) above, within the range that was stated.
By their numbers in this assay, from the lowest: compounds 2, 4 and 1 (each within the scatter of the next). At a limit, above all of these: compound 3.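

With 2-chlorophenyl in place of 4-chlorophenyl on a double-bonded chain carbon bound to a double-bonded chain carbon, this assay gives a 1.7-fold lower number from compound 1 to compound 4 (0.22 log units; within the scatter). Among these compounds, this is the first reading of where the chlorine stands on the aromatic ring rather than which group stands there, and the two placements are not separated at this size of step. Nothing measured here accounts for the step. The compounds shown leave open whether cyano or methoxy, placed in the same way, would stay equally close, and what an amine or a carboxylic acid on the aromatic ring would give.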